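Methylsulfonyl for phenyl: expected cytotoxicity step from compound 3

The source may hold more compounds than are shown below. What is called first, only, known or untested is meant among the compounds shown, and "the series" means these compounds.

In an ADME assay on L6 cells (Rattus norvegicus) for cytotoxicity, read by resazurin assay, with a stated time of 72 h (a higher number here means a weaker inhibitor, a lower number a stronger inhibitor), compound 1 (`CCc1ccc(C(=O)NC(=O)c2ccccc2O)cc1`) gives 70 ug/mL and compound 2 (`CC(C)c1ccc(C(=O)NC(=O)c2ccccc2O)cc1`) gives 19 ug/mL. Compound 3 (`O=C(NC(=O)c1ccccc1O)c1ccc(-c2ccccc2)cc1`) reads > 100 ug/mL, which is a limit of the assay and not a number. Compound 4 (`CS(=O)(=O)c1ccc(C(=O)NC(=O)c2ccccc2O)cc1`) carries methylsulfonyl in place of phenyl on an aromatic carbon, para to a large group: methylsulfonyl in place of phenyl on an aromatic carbon.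

Two measured steps change this same position: an at least 1.4-fold higher number from compound 1 to compound 3 (0.15 log units; that floor lies within the scatter) and an at least 5.2-fold higher number from compound 2 to compound 3 (0.72 log units; beyond the scatter). The first floor lies within the scatter, the second beyond it. Neither involves methylsulfonyl. In this assay, a modest move to a lower number is therefore expected, though none beyond the scatter remains possible. The expected step is an at least 1.4-fold lower number from compound 3 to compound 4 (0.15 log units; that floor lies within the scatter). Compound 4 is estimated at 70 ug/mL, with an expected range of 25 ug/mL to 120 ug/mL.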

Compound 4, half-maximal inhibitory concentration: > 100 ug/mL
Compound 4 ended at the assay's limit; the forecaster's own chance of this, stated with the estimate: 35%; middle value at least 1.4-fold (0.15 log units) from the limit.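

In this assay compound 4 reads > 100 ug/mL, a limit of the assay and not a number. The step between compound 3 and compound 4 cannot be read, because both sit at one limit: the limit of > 100 ug/mL in this assay, at which 2 of the 4 values shown sit. At this position methylsulfonyl, with no ring, thus reaches the same limit as phenyl: replacing isopropyl gives an at least 5.2-fold higher number from compound 2 to compound 4 (0.72 log units; beyond the scatter), and replacing ethyl gives an at least 1.4-fold higher number from compound 1 to compound 4 (0.15 log units; that floor lies within the scatter).

On these data alone, the true values of compound 3 and compound 4 stay open. Also open, as far as these compounds go, is whether an amine, a carboxylic acid or a longer chain here would read below the limit.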